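A few compounds are considered here, and "the series" means these few. Any claim that something is new, unique, unknown or untested is made for them only; others in the source may bear on it.

Three compounds have been measured in a functional assay on MHCC97H cells (Homo sapiens) for antiproliferative activity, read by MTT assay, with a stated time of 48 h; a higher number here means a weaker inhibitor, a lower number a stronger inhibitor:

Compound 1, `COc1ccc2c(/C=C/C(=O)c3cc(OC)c(OC)c(SC)c3)c[nH]c2c1`, gives 112 nM.
Compound 2, `COc1ccc2c(/C=C/C(=O)c3cc(OC)c(OC)c(SC)c3)cn(C)c2c1`, gives 122 nM.
Compound 3, `COc1cc(C(=O)/C(C)=C/c2c[nH]c3ccccc23)cc([Se]C)c1OC`, gives 18 nM.

Compound 1 and compound 2 share one core and differ in a single place: methyl in place of hydrogen on an aromatic nitrogen. This change produced a 1.1-fold higher number from compound 1 to compound 2 (0.04 log units; within the scatter), so the two numbers cannot be told apart by this assay. Compound 3 is built on a different core; the difference between the two cores is not broken down here. Its number is the lowest of the three, and its steps to compound 1 and to compound 2 both lie beyond the scatter, so among the measured compounds compound 3 is the strongest inhibitor.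

Compound 4, `COc1cc(C(=O)/C(C)=C/c2cn(C)c3ccccc23)cc([Se]C)c1OC`, has not yet been measured. It differs from compound 3 in one place: methyl in place of hydrogen on an aromatic nitrogen. The surroundings of the changed atom are described in the same words as for the change from compound 1 to compound 2, so this is the same change carried onto the core of compound 3. Going by the values given here, the one earlier example of it is the only guide available, and it sits on a different core. The step from compound 3 to compound 4 is expected to be a 1.1-fold higher number from compound 3 to compound 4 (0.05 log units; within the scatter) because the earlier example gave a 1.1-fold higher number from compound 1 to compound 2 (0.04 log units; within the scatter). Compound 4 is therefore estimated at 20 nM, most likely between 9 nM and 45 nM. The measurement will show whether the change behaves the same way on this core.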

Compound 4, half-maximal inhibitory concentration: 26 nM
Compound 4: the middle estimate sits 1.3-fold (0.11 log units) below what was measured; the measured number falls inside the stated range.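

In this assay, methyl in place of hydrogen on an aromatic nitrogen gave a 1.4-fold higher number from compound 3 to compound 4 (0.16 log units; within the scatter), so on this core too the number with the methyl cannot be told apart from the number with the hydrogen. Set side by side, the two examples of the change do not differ: the same change on two cores in this assay, a 1.1-fold higher number (0.04 log units; within the scatter) from compound 1 to compound 2 and a 1.4-fold higher number (0.16 log units; within the scatter) from compound 3 to compound 4, 1.3-fold (0.12 log units) apart, within the scatter of two such steps Within this small set, then, the change carried from one core to the other with no step beyond the scatter, but two cores are only two cases, and they show neither how it would behave on a third core nor why the numbers stay together.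

The compounds shown carry only hydrogen or methyl on that nitrogen, so it remains open whether a longer chain, such as ethyl, or a chain ending in an amine or a carboxylic acid, would also leave the number in place. Going by these compounds alone, they also offer no single-place step between the two cores, so which part of the difference between them goes with the lower number of compound 3 remains open as well.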